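The source may report more compounds than this note shows. Statements on the series, on what has been measured and on what is new or still open speak of the compounds shown alone.

Compound 3 `Cn1nc(-c2ccc(C(F)(F)F)cc2)cc1-c1nnc(SCc2ccc(C(F)(F)F)cc2)o1` gives the lowest of the three numbers in a functional assay on Ehrlich cells (Mus musculus) for cytotoxicity, read by MTT assay, with a stated time of 24 h (a lower number here means a stronger inhibitor, a higher number a weaker inhibitor), namely 27300 nM. Compound 1 `Cn1nc(-c2ccc(C(F)(F)F)cc2)cc1-c1nnc(S)o1` gives 75300 nM and compound 2 `Cn1nc(-c2ccc(C(F)(F)F)cc2)cc1-c1nnc(SCc2c(F)cccc2F)o1` gives 38500 nM. The steps of a 2.0-fold lower number from compound 1 to compound 2 (0.29 log units; within the scatter) and a 2.8-fold lower number from compound 1 to compound 3 (0.44 log units; beyond the scatter) set the scale, while a 1.4-fold lower number from compound 2 to compound 3 (0.15 log units; within the scatter) shows that exchanging one substituted phenyl for another on the benzyl group hardly moves this assay. Compound 4 `Cn1nc(-c2ccc(C(F)(F)F)cc2)cc1-c1nnc(SCc2cccc([N+](=O)[O-])c2)o1` carries 3-nitrophenyl in place of 4-(trifluoromethyl)phenyl on a saturated chain carbon bound to a sulfur. Going by the values given here, only the step from compound 2 to compound 3 bears on this change, and it lay within the scatter, so no step beyond the scatter is expected, expressed as a 1.3-fold higher number from compound 3 to compound 4 (0.11 log units; within the scatter). Compound 4 is therefore estimated at 35000 nM in this assay, between 15000 nM and 85000 nM.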

Compound 4, half-maximal inhibitory concentration: > 100000 nM
Compound 4 gave a limit, no number; the forecaster's own chance of this, stated with the estimate: 10%; middle value at least 2.8-fold (0.45 log units) from the limit.
By their numbers in this assay, from the lowest: compounds 3, 2 and 1 (each within the scatter of the next, the first and the last beyond it). At a limit, above all of these: compound 4.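

In this assay compound 4 gives only a limit, not a number: the limit of > 100000 nM in this assay, at which 1 of the 4 values shown sits. The group on the saturated chain carbon bound to a sulfur therefore does matter here, unlike in the earlier exchange of one substituted phenyl for another: the data show an at least 3.6-fold higher number from compound 3 to compound 4 (0.56 log units; beyond the scatter) and an at least 2.5-fold higher number from compound 2 to compound 4 (0.41 log units; beyond the scatter). Against hydrogen on the sulfur, only a floor can be read, an at least 1.3-fold higher number from compound 1 to compound 4 (0.12 log units; that floor lies within the scatter), so 3-nitrobenzyl is not shown to differ from hydrogen. The compounds shown leave open whether a 4-nitrobenzyl, an aminobenzyl or a plain benzyl group on the sulfur would read like compound 3 or like compound 4.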